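The compounds below may be only part of what the source reports. "The series", "measured", "known", "first", "only" and "open" are said of these compounds alone.

Compound 1 `Cc1nn(-c2cccc(CN)c2)c2c(F)c(-c3ccc(N4CCCC4=O)cc3)ccc12`: 702 nM.
Compound 2 `NC(=O)c1nn(-c2ccc3onc(N)c3c2)c2c(F)c(-c3ccc(N4CCCCC4=O)cc3F)ccc12`: > 10000 nM.
Compound 3 `CN(C)Cc1nccn1-c1ccc(-c2ccc3c(C(N)=O)nn(-c4ccc5onc(N)c5c4)c3c2F)c(F)c1`: > 10000 nM.

In an assay on isolated protein for inhibition of Trypsin (Homo sapiens) (a lower number here means a stronger inhibitor, a higher number a weaker inhibitor), compound 1 gives 702 nM. For compound 2 the value > 10000 nM is a limit of the assay and not a number. For compound 3 the value > 10000 nM is likewise a limit. The step that the two limits leave unreadable from compound 2 to compound 3 cannot be read because both its ends sit at the limit of > 10000 nM in this assay, at which 2 of the 3 values shown sit. Compound 3 therefore stands only at the limit, with no number behind it.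

Compound 4 `CN(C)Cc1[nH]ncc1-c1ccc(-c2ccc3c(C(N)=O)nn(-c4ccc5onc(N)c5c4)c3c2F)c(F)c1` is not yet measured. It differs from compound 3 by 5-((dimethylamino)methyl)-1H-pyrazol-4-yl in place of 2-((dimethylamino)methyl)-1H-imidazol-1-yl on an aromatic carbon. Within the data shown here, only the unreadable step from compound 2 to compound 3 touches this position, so no measured step sets the size of the change. Compound 4 is expected to stay at or near the limit, at 10000 nM, within 2000 nM to 30000 nM. The expected step of a number no higher from compound 3 to compound 4 (the limit leaves the size open) is thus estimated as none beyond the scatter.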

Compound 4, inhibition constant: > 10000 nM
Compound 4 gave a limit, no number; the forecaster's own chance of this, stated with the estimate: 70%; the middle value lies on the limit itself.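

Compound 2, compound 3 and compound 4 all stand at a limit and not at a number, so no step among them can be read: the limit of > 10000 nM in this assay, at which 3 of the 4 values shown sit.

On these data alone, whether 5-((dimethylamino)methyl)-1H-pyrazol-4-yl and 2-((dimethylamino)methyl)-1H-imidazol-1-yl differ at all in this read-out remains open.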